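Losing the pyridin-4-yl group: an expected rise in number

The compounds below may be only part of what the source reports. "The series", "measured", "known", "first", "only" and "open" are said of these compounds alone.

In a functional assay on KB cells (Homo sapiens) for cytotoxicity (a lower number here means a stronger inhibitor, a higher number a weaker inhibitor), compound 3 `COc1ccc(S(=O)(=O)N2CCc3cccc(NC(=O)c4ccncc4)c32)cc1` gives 9.6 nM as the lowest number of the three measured compounds. Compound 1 `COc1ccc(S(=O)(=O)N2CCc3cccc(NC(=O)C(C)(C)C)c32)cc1` gives 359 nM in the same test, and compound 2 `COC(=O)c1ccc(C(=O)Nc2cccc3c2N(S(=O)(=O)c2ccc(OC)cc2)CC3)cc1` gives 376 nM there.

Compound 4 `COc1ccc(S(=O)(=O)N2CCc3cccc(NC(C)=O)c32)cc1` is still unmeasured. It carries methyl in place of pyridin-4-yl on a carbonyl carbon, so that ((pyridin-4-yl)carbonyl)amino becomes acetamido: methyl in place of pyridin-4-yl on a carbonyl carbon describes this difference.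

For the measured compounds named here, three measured steps bear on it. Both a 37-fold lower number from compound 1 to compound 3 (1.57 log units; beyond the scatter) and a 39-fold lower number from compound 2 to compound 3 (1.59 log units; beyond the scatter) bring in pyridin-4-yl on that same carbonyl carbon, and both are large. The step of a 1.0-fold higher number from compound 1 to compound 2 (0.02 log units; within the scatter) leaves tert-butyl and 4-(methoxycarbonyl)phenyl indistinguishable in this test. Each of the two groups tried in place of pyridin-4-yl therefore sits far from compound 3, although methyl itself has not been tested. Removing pyridin-4-yl is thus expected to give a large step towards a higher number in this assay, similar in size to those two steps. The expected step is a 47-fold higher number from compound 3 to compound 4 (1.67 log units; beyond the scatter) on this estimate. For compound 4 the estimated value is 450 nM with an expected range from 110 nM to 2000 nM for this measurement.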

Compound 4, half-maximal inhibitory concentration: 89 nM
Beside the measured number, compound 4's estimate is 5.1-fold (0.70 log units) above it, outside the stated range (below it).
By their numbers in this assay, from the lowest: compound 3; then compound 4; then compounds 1 and 2 (each within the scatter of the next).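

In this assay the carbonyl carbon now gives a graded picture and not a simple split: methyl in place of pyridin-4-yl produces a 9.3-fold higher number from compound 3 to compound 4 (0.97 log units; beyond the scatter) and this modest step is smaller than the large ones seen with the two earlier groups. Methyl also parts from those two groups, which could not be told apart, with a 4.2-fold lower number from compound 2 to compound 4 (0.63 log units; beyond the scatter) and with a 4.0-fold lower number from compound 1 to compound 4 (0.61 log units; beyond the scatter) as modest steps in the opposite direction, so this position now shows three levels: pyridin-4-yl lowest, then methyl, then tert-butyl together with 4-(methoxycarbonyl)phenyl. The order does not follow the size of the group, as methyl has larger groups on both sides of it, and a six-membered aromatic ring alone does not set the number, as compound 2 carries one and still stands at the high end.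

The compounds shown do not separate the ring nitrogen of pyridin-4-yl from the ring itself, a question that plain phenyl or pyridin-3-yl on the same carbonyl carbon would address. No evidence at hand accounts for any of these steps.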